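The source may hold more compounds than are shown below. What is called first, only, known or untested is meant among the compounds shown, and "the series" means these compounds.

Measured compounds in an assay on HEK293 cells for inhibition of transient receptor potential cation channel subfamily V member 1 (Homo sapiens); a higher number here means a weaker inhibitor, a lower number a stronger inhibitor: compound 1 `CCCCCCCCC(=O)NCc1cc(Cl)c(O)c(OC)c1` with 631 nM; compound 2 `C#Cc1cc(CNC(=O)CCCCCCCC)cc(OC)c1O` with 2740 nM; compound 3 `C=Cc1cc(CNC(=O)CCCCCCCC)cc(OC)c1O` with 390 nM.

Compound 3 gives the lowest number of the three; one step, a 1.6-fold lower number from compound 1 to compound 3 (0.21 log units; within the scatter), lies within the scatter, while the other, a 7.0-fold lower number from compound 2 to compound 3 (0.85 log units; beyond the scatter), lies beyond it. Compound 4 `CCCCCCCCC(=O)NCc1cc(OC)c(O)c(C(C)=O)c1` carries acetyl in place of vinyl on an aromatic carbon, ortho to a hydroxy group. Among the measured compounds shown here, two steps bear on this position: a 1.6-fold lower number from compound 1 to compound 3 (0.21 log units; within the scatter) and a 7.0-fold lower number from compound 2 to compound 3 (0.85 log units; beyond the scatter). Exchanges at this carbon have moved this assay from within the scatter to a modest shift, with vinyl the best of the three groups seen. Acetyl has no direct precedent here. A modest weakening is therefore expected, a 2.3-fold higher number from compound 3 to compound 4 (0.36 log units; beyond the scatter), and compound 4 is estimated at 900 nM in this assay, within 300 nM to 3000 nM.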

Compound 4, half-maximal inhibitory concentration: 10400 nM
Compound 4: the middle estimate sits 12-fold (1.06 log units) below what was measured; measured number outside the range, above it.
By their numbers in this assay, from the lowest: compounds 3 and 1 (each within the scatter of the next); then compound 2; then compound 4.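

In this assay acetyl on this aromatic carbon, ortho to a hydroxy group, gives the highest number of the four, above vinyl (a 27-fold higher number from compound 3 to compound 4 (1.43 log units; beyond the scatter)), chloro (a 16-fold higher number from compound 1 to compound 4 (1.22 log units; beyond the scatter)) and ethynyl (a 3.8-fold higher number from compound 2 to compound 4 (0.58 log units; beyond the scatter)). Ethynyl therefore no longer marks the upper end at this position, and the range across the groups seen here widens from a modest to a large step. No measurement available here accounts for the acetyl result.

Going by these compounds, whether the higher number follows the carbonyl oxygen or acetyl's extra heavy atom remains open. On these data alone, how a nitrile or an amine on this carbon would rank also stays open.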